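Linker Exchange in a Bile Acid Receptor Agonist Series

This account rests on a few compounds, and the source may have more. Where it says the series, first, only, none or still open, it means among the compounds named here.

Measured compounds:
Compound 1, `Cc1nc(OCc2c(-c3c(Cl)cccc3Cl)noc2C(C)C)ccc1N(C)C(=O)c1ccc(C(=O)O)cc1`, gives 49% in a functional assay on HEK293 cells for agonist activity at Bile acid receptor (Homo sapiens), read by a luciferase reporter; on this read-out lower numbers stand for smaller maximal responses and higher numbers for larger maximal responses.
Compound 2, `CN(Cc1ccc(C(=O)O)cc1)c1ccc(OCc2c(-c3c(Cl)cccc3Cl)noc2C2CC2)nc1C(F)(F)F`, gives 60% in this assay.
Compound 3, `CCN(Cc1ccc(C(=O)O)cc1)c1ccc(OCc2c(-c3c(Cl)cccc3Cl)noc2C2CC2)nc1C(F)(F)F`, gives 43% in this assay.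

Compound 2 stands highest of the three measured numbers; compound 1 sits lower, and compound 3 lower still. Compound 4, `CC(Oc1ccc(C(=O)O)cc1)c1ccc(OCc2c(-c3c(Cl)cccc3Cl)noc2C2CC2)nc1C(F)(F)F`, differs from compound 2 in one place: 1-(4-carboxyphenoxy)ethyl in place of (4-carboxybenzyl)(methyl)amino on an aromatic carbon. For the measured compounds named here, no measured step changes this linker in the same way. The nearest comparison is a number 17 percentage points lower from compound 2 to compound 3 (beyond the scatter), a smaller change at the same nitrogen that already cost efficacy; compound 1, with an amide linker, also sits below compound 2. A modest decrease is therefore expected for compound 4, estimated at 48% (range 28% to 68%), meaning an expected step of a number 12 percentage points lower from compound 2 to compound 4 (beyond the scatter).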

Compound 4, largest response reached (reported as efficacy), in percent of the reference or control that the assay uses: 33%
For compound 4 the middle estimate is 15 percentage points above the measured one; the range from low to high includes it.
By their numbers in this assay, from the lowest: compounds 4, 3 and 1 (each within the scatter of the next, the first and the last beyond it); then compound 2.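

In this assay, replacing (4-carboxybenzyl)(methyl)amino with 1-(4-carboxyphenoxy)ethyl on this aromatic carbon gives a number 27 percentage points lower from compound 2 to compound 4 (beyond the scatter). Both groups hold 12 heavy atoms, one aromatic ring of carbon only, and the same donor and acceptor counts, so these counts alone do not fix the maximal response at this position. No available evidence accounts for the loss. This single exchange alters several linker atoms at once, so their separate contributions remain unresolved. On these data alone, whether a secondary amine or an unbranched benzyl ether linker would hold the response remains open.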